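The source may report more compounds than this note shows. Statements on the series, on what has been measured and on what is new or still open speak of the compounds shown alone.

Compounds measured in an assay on isolated protein for inhibition of Trypsin (Homo sapiens); a lower number here means a stronger inhibitor, a higher number a weaker inhibitor:
- compound 1 `CCOc1cc(C(Nc2ccc3cnccc3c2)C(=O)NS(=O)(=O)c2ccccc2)ccc1OC(C)C`: > 5000 nM, a limit of the assay
- compound 2 `CCOc1cc(C(Nc2ccc3c(N)nccc3c2)C(=O)NS(=O)(=O)c2cccc(S(N)(=O)=O)c2)ccc1OC(C)C`: > 5000 nM, a limit of the assay
- compound 3 `CCOc1cc([C@@H](Nc2ccc3cnccc3c2)C(=O)NS(=O)(=O)c2cccc(S(N)(=O)=O)c2)ccc1OC(C)C`: > 5000 nM, a limit of the assay

Compound 3 stands at a limit in this assay, with no number behind it. Compound 1 stands at a limit as well. Compound 2 also stands at a limit. For the measured compounds named here, all three sit on (the limit of > 5000 nM in this assay, at which 3 of the 3 values shown sit), so none of them can be ordered against the others, and no step between measured compounds has been described.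

The unmeasured compound 4 `CCOc1cc(C(Nc2ccc3cnccc3c2)C(=O)NS(=O)(=O)c2cccc(S(N)(=O)=O)c2)ccc1OC(C)C` differs from compound 3 only in how one centre is drawn: the two compounds have the same atoms and bonds; at least one stereo element is drawn with a configuration in one of them and without one in the other: 1 of 1 stereo elements differ; a stereocentre at a saturated chain carbon is drawn R in compound 3 and without a configuration in compound 4. In words, the two compounds have the same atoms and bonds, and a stereocentre at a saturated chain carbon is drawn R in compound 3 and without a configuration in compound 4.

With the same atoms and bonds, the step from compound 3 to compound 4 in this assay is expected to be none beyond the scatter, and since compound 3 gives only a limit, compound 4 is expected to give a limit too, with a step that the limit leaves unreadable from compound 3 to compound 4. Compound 4 is estimated at 7000 nM, within a range from 4000 nM to 20000 nM.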

Compound 4, inhibition constant: > 5000 nM
Compound 4: a limit, no number; the forecaster's own chance of this, stated with the estimate: 85%; the middle value does not contradict the limit.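

In this assay compound 4 gives > 5000 nM, a limit of the assay and not a number. Its steps from compound 1, compound 2 and compound 3 cannot be read, because all four compounds stand at the same limit: the limit of > 5000 nM in this assay, at which 4 of the 4 values shown sit.

The compounds shown leave open how far the amino group, the sulfamoyl group or the drawn configuration shifts the value in this assay.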